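The source may report more compounds than this note shows. Statements on the series, on what has been measured and on what is new or still open speak of the compounds shown alone.

In a functional assay on HUVEC cells (Homo sapiens) for inhibition, with stated times of 2 h and 72 h (a higher number here means a weaker inhibitor, a lower number a stronger inhibitor), compound 3 `COc1ccc(Nc2nn(C)c3cc(Oc4ccnc5cc(OC)c(OC)cc45)ccc23)cc1` gives > 1000 nM, which is a limit and not a number. Compound 1 `COc1cc2nccc(Oc3ccc4c(NC(=O)c5cccc(C(F)(F)F)c5)nn(C)c4c3)c2cc1OC` gives > 1000 nM, also a limit. Compound 2 `COc1ccc(C(=O)Nc2nn(C)c3cc(Oc4ccnc5cc(OC)c(OC)cc45)ccc23)cc1` gives > 1000 nM, again a limit. Compound 4 `COc1ccc(NC(=O)Nc2nn(C)c3cc(Oc4ccnc5cc(OC)c(OC)cc45)ccc23)cc1` differs from compound 3 on a nitrogen on an aromatic ring: (4-methoxyphenyl)carbamoyl in place of 4-methoxyphenyl on a nitrogen on an aromatic ring. In other words, (4-methoxyphenyl)amino becomes ((4-methoxyphenyl)carbamoyl)amino. The measured steps that bear on this are a step that the two limits leave unreadable from compound 2 to compound 3, a step that the two limits leave unreadable from compound 1 to compound 3 and a step that the two limits leave unreadable from compound 1 to compound 2, so none offers a size or direction to carry over. The data so far show (the limit of > 1000 nM in this assay, at which 3 of the 3 values shown sit). The expected change is therefore small and its direction uncertain, with an estimated a number no higher from compound 3 to compound 4 (the limit leaves the size open). For compound 4 the estimate is 1000 nM, with an expected range of 150 nM to 3000 nM.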

Compound 4, half-maximal inhibitory concentration: > 1000 nM
Compound 4: a limit, no number (the forecaster's own chance of this, stated with the estimate: 60%); the middle value lies on the limit itself.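

No step can be read between compound 4 and compound 1, compound 2 or compound 3, because each value is only a limit: the limit of > 1000 nM in this assay, at which 4 of the 4 values shown sit.

From the compounds shown here alone, how strongly any of these four compounds inhibits, and whether the changes among them alter that strength, stays open.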